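From 2,3-Dimethoxyphenyl to 4-Fluorophenyl on the Shared Core

A few compounds are considered here, and "the series" means these few. Any claim that something is new, unique, unknown or untested is made for them only; others in the source may bear on it.

In a functional assay on HeLa cells (Homo sapiens) for cytotoxicity, read by MTT assay, with a stated time of 48 h (a higher number here means a weaker inhibitor, a lower number a stronger inhibitor), compound 1 (`Cc1cccc(/C=C/[C@](C)(O)CC[C@@H]2[C@@]3(C)CCCC(C)(C)[C@@H]3CC[C@@]2(C)O)c1C`) gives 3700 nM, and compound 2 (`COc1cccc(/C=C/[C@](C)(O)CC[C@@H]2[C@@]3(C)CCCC(C)(C)[C@@H]3CC[C@@]2(C)O)c1OC`) gives 3880 nM. Among the compounds with values here, the two stand level, as the only measured step shows: a 1.0-fold higher number from compound 1 to compound 2 (0.02 log units; within the scatter). Compound 3 (`CC1(C)CCC[C@]2(C)[C@@H](CC[C@@](C)(O)/C=C/c3ccc(F)cc3)[C@](C)(O)CC[C@@H]12`) keeps the shared core but carries 4-fluorophenyl in place of 2,3-dimethoxyphenyl on a double-bonded chain carbon bound to a double-bonded chain carbon. Within the data shown here, only the step from 2,3-dimethylphenyl to 2,3-dimethoxyphenyl bears on this change, since it concerns the same place. That step, a 1.0-fold higher number from compound 1 to compound 2 (0.02 log units; within the scatter), left the number within the scatter. Among the measured compounds shown here, no measured compound carries fluorine, so this evidence is thin, and no shift beyond the scatter is expected in this assay. The estimated step is a 1.0-fold lower number from compound 2 to compound 3 (0.01 log units; within the scatter). For compound 3 the estimated value is 3800 nM, with an expected range from 1700 nM to 8500 nM.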

Compound 3, half-maximal inhibitory concentration: 3460 nM
Compound 3: middle estimate off by 1.1-fold (0.04 log units), on the high side; the measured number falls inside the stated range.
By their numbers in this assay, from the lowest: compounds 3, 1 and 2 (each within the scatter of the next).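

Compound 3 brings the first fluorine to this place, on a double-bonded chain carbon bound to a double-bonded chain carbon, and the change from 10 heavy atoms and 2 hydrogen-bond acceptors to 7 heavy atoms and 0 hydrogen-bond acceptors still gives a 1.1-fold lower number from compound 2 to compound 3 (0.05 log units; within the scatter) in this assay and a 1.1-fold lower number from compound 1 to compound 3 (0.03 log units; within the scatter). Among the compounds shown, 2,3-dimethylphenyl, 2,3-dimethoxyphenyl and 4-fluorophenyl therefore read alike at this place, with no compound going against that. Nothing measured here bears on why these groups give such similar numbers.

The compounds shown leave open whether the number would stay level with an amine or a carboxylic acid on the phenyl ring, or with a longer chain in place of that ring. They also leave open what changes at the shared core would do, since all three compounds keep it.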